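This account rests on a few compounds, and the source may have more. Where it says the series, first, only, none or still open, it means among the compounds named here.

Among the measured compounds shown here, compound 1 `O=c1c(-c2cccc([N+](=O)[O-])c2)nc2ccccc2n1Cc1ccccc1` gives 9 nM in an assay on cells for activation of Cystic fibrosis transmembrane conductance regulator (Homo sapiens), read by fluorescence, with a stated time of 10 min (a lower number here means that less compound is needed, a higher number that more compound is needed for the effect), the lowest of the two numbers known so far. Compound 2 `O=c1c(-c2ccccc2)nc2ccccc2n1Cc1ccccc1` gives 5000 nM in this assay. The step of a 560-fold higher number from compound 1 to compound 2 (2.74 log units; beyond the scatter) went with hydrogen in place of nitro on an aromatic carbon. Compound 3 `O=c1c(-c2cccc([N+](=O)[O-])c2)nc2ccc(Br)cc2n1Cc1ccccc1` differs from compound 1 by bromo in place of hydrogen on an aromatic carbon. For the measured compounds named here, no measured step touches that place, so the one known step does not bear on it. The change is expected to leave the number close to that of compound 1, with no change at the digits printed from compound 1 to compound 3 (within the scatter) not beyond the scatter. Compound 3 is therefore estimated at 9 nM, within 3 nM to 30 nM.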

Compound 3, half-maximal effective concentration: "not active" (no number reported)
No number was reported for compound 3; there is nothing to compare the estimate with.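

Among the compounds shown here, compound 3 was reported as not active in this assay without a number, so no step from compound 1 to compound 3 can be read. Nothing at hand explains this result. The compounds shown leave open whether other groups at that place would keep the activity of compound 1.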